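Moving the Chlorine Along the Benzyl Group of Compound 3

A few compounds are considered here, and "the series" means these few. Any claim that something is new, unique, unknown or untested is made for them only; others in the source may bear on it.

Of the compounds shown here, three built on one shared core have been measured in a functional assay on the whole organism (artery, strain albino) with Rattus norvegicus as the target, with a stated time of 600 min, at a dose of 10 mg/kg by the oral route; a higher number here means more inhibition at the dose given (going by the name of the read-out), a lower number less inhibition. Compound 1 `COc1ccc(C2N=C(SCc3ccc(Cl)cc3)NC(C)=C2C(=O)Nc2ccc(F)cc2)cc1OC` gives 26.7%. Compound 2 `CC1=C(C(=O)Nc2ccc(F)cc2)C(c2ccc([N+](=O)[O-])cc2)N=C(SCc2ccccc2)N1` gives 32.3%. Compound 3 `CC1=C(C(=O)Nc2ccc(F)cc2)C(c2ccc([N+](=O)[O-])cc2)N=C(SCc2ccccc2Cl)N1` gives 17.4%, the lowest of the three numbers; its gap to compound 1 lies within the scatter, while its gap to compound 2 lies beyond it.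

Compound 4 `CC1=C(C(=O)Nc2ccc(F)cc2)C(c2ccc([N+](=O)[O-])cc2)N=C(SCc2ccc(Cl)cc2)N1` has not yet been measured. It differs from compound 3 in a single place: 4-chlorophenyl in place of 2-chlorophenyl on a saturated chain carbon bound to a sulfur. The only measured step among these compounds is a number 14.9 percentage points lower from compound 2 to compound 3 (beyond the scatter), which added the chlorine to the benzyl group in the first place. Among the compounds with values here, no measured step moves a chlorine from one place on that ring to another, so the size of the present step is uncertain. Compound 1 also carries a (4-chlorobenzyl)sulfanyl group, but it differs from compound 4 elsewhere as well, so its value only hints at the level to expect.

Compound 4 is therefore expected to give 25%, somewhere between 12% and 38%. The expected step is a number 7.6 percentage points higher from compound 3 to compound 4 (within the scatter), which would not reach beyond the scatter.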

Compound 4, a percentage reported as inhibition, in the whole organism at one dose (the size of the read-out at that dose, not a potency): 28.2%
Compound 4: middle estimate off by 3.2 percentage points, on the low side; the range from low to high includes it.
By their numbers in this assay, from the lowest: compounds 3, 1, 4 and 2 (each within the scatter of the next, the first and the last beyond it).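

In this assay, the place of the chlorine on the benzyl group matters, with 4-chlorophenyl in place of 2-chlorophenyl giving a number 10.8 percentage points higher from compound 3 to compound 4 (beyond the scatter). The drop seen on adding chlorine therefore belongs to 2-chlorophenyl and does not extend to every chlorine on this ring: 4-chlorophenyl against the bare phenyl ring gives a number 4.1 percentage points lower from compound 2 to compound 4 (within the scatter), and with the (4-chlorobenzyl)sulfanyl group in place, 4-nitrophenyl in place of 3,4-dimethoxyphenyl gives a number 1.5 percentage points higher from compound 1 to compound 4 (within the scatter). Nothing available here bears on why the place of the chlorine matters.

On these data alone, whether a fluorine, a methyl group or a carboxylic acid in place of this chlorine would behave like it remains open. So does whether the gap between 2-chlorophenyl and 4-chlorophenyl holds with 3,4-dimethoxyphenyl on the shared core.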